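The compounds below may be only part of what the source reports. "The series", "measured", "known", "first", "only" and "open" are said of these compounds alone.

Measured so far:
compound 1 `CCOC(=O)c1cc(-c2cc(OC)c(OC)c(OC)c2)c(-c2cccc(Br)c2)s1`, > 100000 nM
compound 2 `CCOC(=O)c1cc(-c2cc(OC)c(OC)c(OC)c2)c(-c2ccc(OC)c([N+](=O)[O-])c2)s1`, 18100 nM
compound 3 `CCOC(=O)c1cc(-c2cc(OC)c(OC)c(OC)c2)c(-c2ccc3ccccc3c2)s1`, 4340 nM

In a functional assay on SGC-7901 cells (Homo sapiens) for antiproliferative activity, read by MTT assay, with a stated time of 72 h (a higher number here means a weaker inhibitor, a lower number a stronger inhibitor), compound 1 gives only a limit, > 100000 nM; this is the limit of the assay and not a number, (the limit of > 100000 nM in this assay, at which 1 of the 3 values shown sits). Compound 1 therefore stands at the weak end of the three, while compound 2 and compound 3 give numbers: the steps of an at least 5.5-fold lower number from compound 1 to compound 2 (0.74 log units; beyond the scatter) and an at least 23-fold lower number from compound 1 to compound 3 (1.36 log units; beyond the scatter) both lie beyond the scatter, as does a 4.2-fold lower number from compound 2 to compound 3 (0.62 log units; beyond the scatter). All three measured steps concern the aryl group on the shared core; none touches the ethoxycarbonyl.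

Compound 4 `COc1cc(-c2ccsc2-c2cccc(Br)c2)cc(OC)c1OC` differs from compound 1 in one place: hydrogen in place of ethoxycarbonyl on an aromatic carbon. Going by the values given here, no measured step bears on this change, so there is no step here whose size can guide the expectation, and the account can only rest on where compound 1 stands. Since compound 1 itself reports only a limit, the expected step of a number no higher from compound 1 to compound 4 (the limit leaves the size open) for compound 4 is uncertain in direction and size. With nothing to point one way, compound 4 is estimated at 100000 nM, in a range from 15000 nM to 500000 nM, with a real chance that this assay again returns only a limit.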

Compound 4, half-maximal inhibitory concentration: 46100 nM
The estimate for compound 4 lay 2.2-fold (0.34 log units) above the measured number; low and high end bracket the measured number.
By their numbers in this assay, from the lowest: compound 3; then compound 2; then compound 4. At a limit, above all of these: compound 1.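

Going by these compounds alone, until now every measured step concerned the aryl group on the shared core; compound 4 is the first to change the other site, an aromatic carbon of a five-membered aromatic ring with 1 sulfur, next to the ring sulfur. In this assay, hydrogen in place of ethoxycarbonyl gives an at least 2.1-fold lower number from compound 1 to compound 4 (0.33 log units; beyond the scatter), so with the 3-bromophenyl group in place, the loss of the ethoxycarbonyl does not leave the compound at the limit, and the step lies beyond the scatter. Compound 1 gives > 100000 nM, which is a limit of the assay and not a number, so the step has a known direction but no known full size: the limit of > 100000 nM in this assay, at which 1 of the 4 values shown sits.

The compounds shown leave open how a carboxylic acid, a primary amide or a methyl group on this same carbon would compare with ethoxycarbonyl and with hydrogen. Within the data shown here, they also leave open whether hydrogen in place of ethoxycarbonyl would run the same way with the naphthalen-2-yl group of compound 3 or the 4-methoxy-3-nitrophenyl group of compound 2, as the only pair that speaks to this change carries 3-bromophenyl.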